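The compounds below may be only part of what the source reports. "The series", "measured", "known", "first", "only" and "open" are said of these compounds alone.

Measured so far:
compound 1, `O[C@@H]1[C@@H](O)[C@H](Oc2ccc(S)c3ccccc23)OC[C@H]1O`: 55 uM
compound 2, `Oc1cccc2cccc(S[C@@H]3OC[C@@H](O)[C@H](O)[C@H]3O)c12`: 225 uM

Both numbers come from a functional assay on T-24 cells (Homo sapiens) for antiproliferative activity, read by crystal violet staining, with a stated time of 96 h; on this read-out higher numbers stand for an effect only at larger amounts of compound and lower numbers for an effect already at smaller amounts. Compound 1 stands at the lower of the two numbers; in this assay compound 2 gives a number higher than that of compound 1, and the gap between the two lies beyond the usual scatter of repeated measurements. Among the measured compounds shown here, the two structures differ in more than one place, so no single step connects them.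

Compound 3, `CCCSc1ccc(O[C@@H]2OC[C@@H](O)[C@H](O)[C@H]2O)c2ccccc12`, has yet to be measured in this assay. It differs from compound 1 in one place: propyl in place of hydrogen on a sulfur. For the measured compounds named here, no pair among the measured compounds carries the same change, so there is no measured step to lean on. With nothing to set its direction, the step from compound 1 to compound 3 is expected to stay within the scatter, in either direction. For compound 3 in this assay the estimate is 45 uM, in the range 15 uM to 130 uM. The expected step is a 1.2-fold lower number from compound 1 to compound 3 (0.09 log units; within the scatter).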

Compound 3, concentration for half-maximal effect: 30 uM
Beside the measured number, compound 3's estimate is 1.5-fold (0.18 log units) above it, and the stated range covers the measured number.
By their numbers in this assay, from the lowest: compounds 3 and 1 (each within the scatter of the next); then compound 2.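

In this assay the sulfur of compound 1 takes propyl in place of hydrogen with no shift that can be told from the usual scatter (a 1.8-fold lower number from compound 1 to compound 3 (0.26 log units; within the scatter)). Among the compounds shown here, this is the first one-place step, and it shows that the hydrogen on this sulfur is not required to keep the number at this level and that propylsulfanyl is accepted at this position. Nothing at hand explains this outcome.

From the compounds shown here alone, one step sets no trend with chain size, so it remains open whether a longer chain such as octyl, or a branched one such as isopropyl, would behave the same way. Also open, going by these compounds, is what an amine or a carboxylic acid at the end of the propyl chain would do to the number.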